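A few compounds are considered here, and "the series" means these few. Any claim that something is new, unique, unknown or untested is made for them only; others in the source may bear on it.

Compound 1 `Cc1oc(-c2c(C)c(C)c(C)c(C)c2C)nc1CN1CCC(C(=O)NCCCN2C[C@H](C)C[C@H](C)C2)CC1` and compound 2 `CCCN(CCC)CCNC(=O)C1CCN(Cc2nc(-c3ccccc3C)oc2C)CC1` have both been measured in a physicochemical assay for permeability, using PAMPA; a higher number here means that the compound crosses the layer faster, a lower number that the compound crosses the layer more slowly. In that measurement compound 1 gives 455 10^-6 cm/s, and compound 2 gives 913 10^-6 cm/s. Compound 1 therefore holds the lower of the two numbers, but its gap to compound 2 lies within the usual scatter of repeated measurements, so the two compounds cannot be separated on these data. Compound 3 `Cc1ccc(-c2nc(CN3CCC(C(=O)NCCCN4C[C@H](C)C[C@H](C)C4)CC3)c(C)o2)cc1C` has not yet been measured in this assay. It differs from compound 1 in a single place: 3,4-dimethylphenyl in place of 2,3,4,5,6-pentamethylphenyl on an aromatic carbon. Among the measured compounds shown here, no pair of measured compounds in this set differs in only one place, so there is no measured step that could serve as a guide for this change. The group that enters is the smaller of the two by the counts given, while donors, acceptors and charge stay the same. Since nothing measured here speaks for a large effect, the step is expected to be small, with no change beyond the scatter in either direction, as a 1.1-fold higher number from compound 1 to compound 3 (0.04 log units; within the scatter) expresses. Compound 3 is accordingly estimated at 500 10^-6 cm/s in this assay, with an expected range from 250 10^-6 cm/s to 1000 10^-6 cm/s.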

Compound 3, apparent permeability: 219 10^-6 cm/s
Beside the measured number, compound 3's estimate is 2.3-fold (0.36 log units) above it; measured number outside the range, below it.
By their numbers in this assay, from the lowest: compound 3; then compounds 1 and 2 (each within the scatter of the next).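

In this assay, the aromatic carbon next to the ring nitrogen and next to the ring oxygen of the five-membered aromatic ring now has its first measured step: 3,4-dimethylphenyl in place of 2,3,4,5,6-pentamethylphenyl gives a 2.1-fold lower number from compound 1 to compound 3 (0.32 log units; beyond the scatter). The number at this position therefore responds to a change of this group, modestly but beyond the scatter, even though the hydrogen-bond donor, hydrogen-bond acceptor and net charge counts stay the same and a six-membered aromatic ring of carbon only remains in place. The group with fewer heavy atoms carries the lower number and the group with more heavy atoms the higher one, but this is a single step and no explanation for it is available.

The two groups differ both in how many methyl groups they carry and in where those groups sit, so this step cannot separate the two differences. Also open, on these data alone, is how the number would respond on the same core to an unsubstituted phenyl, which has no methyl groups, or to a pyridyl ring, which has a ring nitrogen.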